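This account rests on a few compounds, and the source may have more. Where it says the series, first, only, none or still open, it means among the compounds named here.

Compound 3 `Cc1cc(S(N)(=O)=O)ccc1NC(=O)COc1ccc(F)cc1Oc1ccc2cc(C#N)ccc2c1` sits at a limit in an ADME assay on C8166 cells (Homo sapiens) for cytotoxicity, read by MTT assay; on this read-out higher numbers stand for lower toxicity in this test and lower numbers for higher toxicity in this test: its value of > 395000 nM is a boundary of the test, not a number. Compound 1 `Cc1cc(S(N)(=O)=O)ccc1NC(=O)COc1ccc(F)cc1Oc1ccc2cc(Br)ccc2c1` likewise stops at a limit of > 357000 nM. Compound 2 `Cc1cc(S(N)(=O)=O)ccc1NC(=O)COc1ccc(F)cc1Oc1ccc2ccccc2c1Br` gives a number, 39500 nM. Compound 4 `Cc1cc(S(N)(=O)=O)ccc1NC(=O)COc1ccc(F)cc1Oc1c(C)cc2ccccc2c1Cl` differs from compound 3 in one place: 1-chloro-3-methylnaphthalen-2-yl in place of 6-cyanonaphthalen-2-yl on an oxygen on an aromatic ring. Among the measured compounds shown here, two measured steps bear on this change. In the step of an at least 9.0-fold lower number from compound 1 to compound 2 (0.95 log units; beyond the scatter) the 1-bromonaphthalen-2-yl group entered and the number fell; in the step of an at least 10-fold higher number from compound 2 to compound 3 (1.00 log units; beyond the scatter) it left and the number rose. Compound 4 carries the related 1-chloro-3-methylnaphthalen-2-yl group, so a lower number is expected, a step of an at least 7.9-fold lower number from compound 3 to compound 4 (0.89 log units; beyond the scatter). Compound 4 is therefore estimated at 50000 nM, between 15000 nM and 250000 nM.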

Compound 4, half-maximal cytotoxic concentration: 55600 nM
Estimate against measurement, compound 4: 1.1-fold (0.05 log units) below, and the stated range covers the measured number.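

In this assay, the lower numbers, which stand for higher toxicity in this test, no longer belong to the 1-bromonaphthalen-2-yl group alone: the 1-chloro-3-methylnaphthalen-2-yl group gives an at least 7.1-fold lower number from compound 3 to compound 4 (0.85 log units; beyond the scatter) and an at least 6.4-fold lower number from compound 1 to compound 4 (0.80 log units; beyond the scatter). Against the bromo group itself, the change gives a 1.4-fold higher number from compound 2 to compound 4 (0.15 log units; within the scatter), so these two groups cannot be told apart here. Compound 1 and compound 3 stand at limits of the test, and the steps from them give only a minimum size.

Still open is whether the chlorine or the methyl matters more, as 1-chloronaphthalen-2-yl without the methyl is not among the compounds shown. Also open, from the compounds shown here alone, is whether 1-cyanonaphthalen-2-yl or 1-aminonaphthalen-2-yl would give a similarly low number.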